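The source may report more compounds than this note shows. Statements on the series, on what has been measured and on what is new or still open speak of the compounds shown alone.

Compound 1, `C[C@@H](Cn1ccc(-c2ccc(C#N)c(Cl)c2)n1)NC(=O)C1CC(=O)C1`, gives 22500 nM in a functional assay on VCaP cells (Homo sapiens) for antiproliferative activity, read by CCK-8 assay, with a stated time of 6 days; a lower number here means a stronger inhibitor, a higher number a weaker inhibitor.
Compound 2, `C[C@@H](Cn1ccc(-c2ccc(C#N)c(Cl)c2)n1)Nc1ccccc1`, gives a reading in this assay that is a limit of the assay and not a number, > 30000 nM.

Compound 2 therefore stands at the edge of what this assay can report: the limit of > 30000 nM in this assay, at which 1 of the 2 values shown sits. Within the data shown here, the only measured step, an at least 1.3-fold higher number from compound 1 to compound 2 (0.12 log units; that floor lies within the scatter), is itself a floor that lies within the scatter, so it sets neither a size nor a direction for what follows.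

Compound 3, `C[C@@H](Cn1ccc(-c2ccc(C#N)c(Cl)c2)n1)Nc1cccnc1`, differs from compound 2 by pyridin-3-yl in place of phenyl on an amine nitrogen. Among the measured compounds shown here, no measured step here touches a pyridin-3-yl group or any ring with a hetero atom, so the size of the step in this assay has no direct precedent. With compound 2 already at the assay limit, the step is expected to be a number no higher from compound 2 to compound 3 (the limit leaves the size open), that is, nothing beyond the scatter. Compound 3 is accordingly estimated at about 30000 nM in this assay, with a range from 10000 nM to 80000 nM, and a fair chance that this assay again reports only a limit rather than a number.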

Compound 3, half-maximal inhibitory concentration: > 30000 nM
Compound 3 was reported as a limit; the forecaster's own chance of this, stated with the estimate: 60%; the middle value sits exactly at the limit.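

Compound 3, with pyridin-3-yl in place of phenyl on the amine nitrogen, gives > 30000 nM in this assay, which is a limit of the assay and not a number. The step between the limits of compound 2 and compound 3 cannot be read, so a ring with a hetero atom and a hydrogen-bond acceptor at this position brings no readable value, and the comparison with phenyl stays unresolved. Pyridin-3-yl in place of (3-oxocyclobutyl)carbonyl on the amine nitrogen gives an at least 1.3-fold higher number from compound 1 to compound 3 (0.12 log units; that floor lies within the scatter), so this change, like the one to phenyl, sets only a floor, and the readings now gather at the assay's ceiling: the limit of > 30000 nM in this assay, at which 2 of the 3 values shown sit.

The compounds shown leave open how far compound 2 and compound 3 lie past their limits, and so whether the ring nitrogen of pyridin-3-yl matters here at all. They also leave open whether a different group on this amine nitrogen, such as a pyrimidin-5-yl ring, an acetyl group or a longer chain, would read clearly stronger than compound 1 at 22500 nM.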